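This account rests on a few compounds, and the source may have more. Where it says the series, first, only, none or still open, it means among the compounds named here.

Compound 2 `O=C(O)c1ccc2noc(-c3ccc(N4CCCCC4)cc3)c2c1` gives the higher of the two numbers recorded so far in an assay for inhibition of inositol hexakisphosphate kinase 3 (Homo sapiens), read by colorimetric assay, coupled enzyme assay and malachite green, with a stated time of 120 min, in the presence of a further agent that is not named here; a lower number here means a stronger inhibitor, a higher number a weaker inhibitor: compound 2 gives 1790 nM. Compound 1 `O=C(O)/C=C/c1ccc2noc(-c3ccc(Oc4ccccc4)cc3)c2c1` gives 760 nM in this assay, a number that stands beyond the usual scatter below that of compound 2, though the two structures differ in more than one place, so the gap cannot be assigned to any single change. The next compound, compound 3 `O=C(O)c1ccc2noc(-c3ccc(Oc4ccccc4)cc3)c2c1`, is reached from compound 2 by phenoxy in place of piperidin-1-yl on an aromatic carbon. Compound 3 shares this phenoxy group with compound 1 and the directly attached carboxylic acid with compound 2. Among the compounds with values here, no measured pair isolates this change. Compound 3 is therefore expected to fall close to compound 2, with a modest drop that may not exceed the scatter, an expected step of a 1.6-fold lower number from compound 2 to compound 3 (0.21 log units; within the scatter). The estimate for compound 3 in this assay is 1100 nM, with a range from 350 nM to 3500 nM.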

Compound 3, half-maximal inhibitory concentration: 550 nM
Compound 3: middle estimate off by 2.0-fold (0.30 log units), on the high side, and the stated range covers the measured number.
By their numbers in this assay, from the lowest: compounds 3 and 1 (each within the scatter of the next); then compound 2.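

In this assay, within the data shown here, phenoxy in place of piperidin-1-yl on the aromatic carbon gives a 3.3-fold lower number from compound 2 to compound 3 (0.51 log units; beyond the scatter), the first step that changes this position alone, and it shows that the number responds to the group carried there. Carboxy in place of 2-carboxyethenyl gives a 1.4-fold lower number from compound 1 to compound 3 (0.14 log units; within the scatter), so with phenoxy held in place, this assay does not tell these two acid-bearing groups apart. No measurement at hand bears on what lies behind either step.

Going by these compounds, what an anilino, benzyloxy or morpholin-4-yl group would give at the position para to a large group remains open, so the step cannot yet be assigned to the aromatic ring or to the oxygen of phenoxy. On these data alone, whether an amide or a tetrazole could stand in for the carboxylic acid also remains open.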